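This account rests on a few compounds, and the source may have more. Where it says the series, first, only, none or still open, it means among the compounds named here.

Three compounds share one core and differ in the group on the sulfonyl sulfur: compound 1 `O=S(=O)(c1ccc(F)cc1)c1cnc2cc(F)ccc2c1-c1ccc(F)cc1`, compound 2 `O=S(=O)(c1cc(Cl)cc(Cl)c1)c1cnc2cc(F)ccc2c1-c1ccc(F)cc1` and compound 3 `COc1ccc(S(=O)(=O)c2cnc3cc(F)ccc3c2-c2ccc(F)cc2)cc1`. In an ADME assay on microsomes from liver (Homo sapiens) for metabolic stability, tested at 2.5 uM (a higher number here means faster removal of the compound, a lower number slower removal), compound 1 gives 1.34 mL/min, compound 2 gives 0.18 mL/min and compound 3 gives 1.71 mL/min. Compound 2 stands lowest of the three, with a 7.4-fold lower number from compound 1 to compound 2 (0.87 log units; beyond the scatter) and a 9.5-fold higher number from compound 2 to compound 3 (0.98 log units; beyond the scatter), while a 1.3-fold higher number from compound 1 to compound 3 (0.11 log units; within the scatter). Compound 4 `O=S(=O)(c1cc(Cl)cc(Cl)c1)c1cnc2cc(F)ccc2c1-c1cccc(Cl)c1` keeps the 3,5-dichlorophenyl of compound 2 and changes the other ring: 3-chlorophenyl in place of 4-fluorophenyl on an aromatic carbon. Among the compounds with values here, no measured step touches that ring, so the measured steps give no direct guide, and the expected step in this assay is a 1.4-fold higher number from compound 2 to compound 4 (0.14 log units; within the scatter), none beyond the scatter. Compound 4 is therefore estimated at 0.25 mL/min, within 0.1 mL/min to 0.6 mL/min.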

Compound 4, intrinsic clearance in a liver preparation (reported as CLH), per the amount of preparation that the assay uses: 0.93 mL/min
Compound 4: the middle estimate sits 3.7-fold (0.57 log units) below what was measured, and the stated range ends below it.
By their numbers in this assay, from the lowest: compound 2; then compounds 4, 1 and 3 (each within the scatter of the next).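

The aromatic carbon opposite the ring nitrogen matters in this assay: with the 3,5-dichlorophenyl on the sulfonyl sulfur held constant, 3-chlorophenyl in place of 4-fluorophenyl gives a 5.2-fold higher number from compound 2 to compound 4 (0.71 log units; beyond the scatter) and so shows that the low number of compound 2 also depends on this second ring. Nothing measured here tells why this change has such an effect. Whether the chlorine itself or its place on the ring accounts for the step remains open, as a 4-chlorophenyl or 3-fluorophenyl group at this position would be needed to separate the two. Also open, as far as these compounds go, is how an amine or a carboxylic acid on this ring would behave.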